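Working notes on compound 2 and the untested compound 3

This account rests on a few compounds, and the source may have more. Where it says the series, first, only, none or still open, it means among the compounds named here.

Measured so far:
- compound 1, `CCC/N=C(/NC#N)NCCCCn1nc(-c2ccccc2)ccc1=O`
- compound 2, `CC/N=C(/NC#N)NCCCCCn1nc(-c2ccccc2)ccc1=O`

Among the compounds with values here, in a functional assay on the whole organism (stomach) with Rattus norvegicus as the target (a higher number here means that more compound is needed for the effect, a lower number that less compound is needed), compound 2 gives 100 mg/kg, the only actual number in the set. For compound 1 the value > 100 mg/kg in this assay is a limit of the assay and not a number (the limit of > 100 mg/kg in this assay, at which 1 of the 2 values shown sits). Within the data shown here, no step between two measured compounds can therefore be stated; the two values show only that compound 2 sits at the one number recorded and compound 1 sits at the limit.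

Compound 3, `CN(C)/C(=N/CCCCCCn1nc(-c2ccccc2)ccc1=O)NC#N`, differs from compound 2 as follows: a group of 9 heavy atoms (5 carbon, 4 nitrogen; no ring) in place of a group of 8 heavy atoms (4 carbon, 4 nitrogen; no ring), on a saturated chain carbon, five bonds along the chain from an aromatic nitrogen

Among the measured compounds shown here, with no measured step to lean on, the expected change from compound 2 to compound 3 is none beyond the usual scatter, and the step that the estimate implies is no change at the digits printed from compound 2 to compound 3 (within the scatter). Compound 3 is expected to give about 100 mg/kg in this assay, within a range from 40 mg/kg to 250 mg/kg, with a real chance that only a limit is reported.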

Compound 3, dose for half-maximal effect: 93.1 mg/kg
Compound 3: the middle estimate sits 1.1-fold (0.03 log units) above what was measured; the measured number falls inside the stated range.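

In this assay, a group of 9 heavy atoms (5 carbon, 4 nitrogen; no ring) in place of a group of 8 heavy atoms (4 carbon, 4 nitrogen; no ring), on a saturated chain carbon, five bonds along the chain from an aromatic nitrogen, gives a 1.1-fold lower number from compound 2 to compound 3 (0.03 log units; within the scatter). Within the data shown here, this is the only step that can be read, and it shows that this exchange, in which the entering group has 1 hydrogen-bond donor and the leaving group has 2, leaves the dose within the scatter. Compound 1 carries a limit of the assay and not a number, so steps involving it cannot be read: the limit of > 100 mg/kg in this assay, at which 1 of the 3 values shown sits.

One step at one position cannot show whether the flat result extends to other groups. As far as these compounds go, whether an amine or a carboxylic acid at this position would shift this assay beyond the scatter remains open.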